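The compounds below may be only part of what the source reports. "The series", "measured", "known", "first", "only" and "open" are said of these compounds alone.

Measured compounds:
- compound 1, `Cc1nc(N(C)c2ccc([Se]C#N)c(Cl)c2)c2ccccc2n1`: 11 nM
- compound 2, `COc1ccc(N(C)c2nc(C)nc3ccccc23)cc1OCCN`: 343 nM
- compound 3, `CN(c1ccc([Se]C#N)cc1)c1nc(C2CC2)nc2ccccc12`: 51 nM

In a functional assay on RKO cells (Homo sapiens) for inhibition, read by MTT assay, with a stated time of 48 h (on this read-out higher numbers stand for weaker inhibition and lower numbers for stronger inhibition), compound 2 gives the highest of the three numbers. Compound 3 stands nearest to it, with a lower number that lies beyond the scatter, and compound 1 stands furthest, with a lower number that also lies beyond the scatter. Compounds 1 and 3 both carry a group with selenium and a nitrile; compound 2 carries none, so the three values alone do not separate the shared core from that group.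

The unmeasured compound 4, `COc1ccc(N(C)c2nc(C)nc3ccccc23)cc1C[Se]C#N`, differs from compound 2 in one place: a group of 4 heavy atoms (2 carbon, 1 nitrogen, 1 selenium; no ring) in place of a group of 4 heavy atoms (2 carbon, 1 nitrogen, 1 oxygen; no ring), on an aromatic carbon. Within the data shown here, no measured pair shows this exact exchange, so the size of the step can only be expected from the standing of compound 2 against compounds 1 and 3 in this assay.

For compound 4 the number in this assay is expected to fall, by a step of a 5.7-fold lower number from compound 2 to compound 4 (0.76 log units; beyond the scatter), beyond the scatter. The estimate for compound 4 is 60 nM, with a range from 15 nM to 250 nM.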

Compound 4, half-maximal inhibitory concentration: 316 nM
The estimate for compound 4 lay 5.3-fold (0.72 log units) below the measured number, outside the stated range (above it).
By their numbers in this assay, from the lowest: compound 1; then compound 3; then compounds 4 and 2 (each within the scatter of the next).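

In this assay, replacing the 2-aminoethoxy group with the group of carbon, selenium and nitrile on this aromatic carbon, ortho to a methoxy group, gives a 1.1-fold lower number from compound 2 to compound 4 (0.04 log units; within the scatter). Among these compounds, at this position the exchange therefore leaves the read-out unchanged within the scatter, and on this scaffold the presence of the selenium and nitrile group alone does not move the number, a separation the earlier compounds could not make. Nothing at hand explains why this exchange leaves the number in place.

Going by these compounds, it remains open whether a carboxylic acid, a simple amine or a longer chain ending in an amine would also hold the number at this position. Also open, on these data alone, is whether the selenium and nitrile group would behave the same way elsewhere on this aromatic ring.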